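Swapping the amine on the core for a phenylpiperidine

A few compounds are considered here, and "the series" means these few. Any claim that something is new, unique, unknown or untested is made for them only; others in the source may bear on it.

Measured compounds:
compound 1 `Cc1ccc(Cl)cc1Nc1nc(C(F)(F)F)ccc1CNC(=O)C(C)c1ccc(NS(C)(=O)=O)c(F)c1` gives 14 nM
compound 2 `CCCN(CCC)c1nc(C(F)(F)F)ccc1CNC(=O)C(C)c1ccc(NS(C)(=O)=O)c(F)c1` gives 0.2 nM
compound 3 `CC1CCCN1c1nc(C(F)(F)F)ccc1CNC(=O)[C@@H](C)c1ccc(NS(C)(=O)=O)c(F)c1` gives 0.3 nM

All three were tested in a functional assay on CHO-K1 cells for antagonist activity at transient receptor potential cation channel subfamily V member 1 (Homo sapiens), read by FLIPR; on this read-out higher numbers stand for weaker inhibition and lower numbers for stronger inhibition. Compound 2 shows the lowest of the three numbers, but compound 3 sits within the usual scatter of it, so the two cannot be ranked; only compound 1 stands clearly apart. Compound 4 `CC(C(=O)NCc1ccc(C(F)(F)F)nc1N1CCC(c2ccccc2)CC1)c1ccc(NS(C)(=O)=O)c(F)c1` differs from compound 2 at one point: 4-phenylpiperidin-1-yl in place of dipropylamino on an aromatic carbon. Among the compounds with values here, the one measured step at this same carbon, a 70-fold lower number from compound 1 to compound 2 (1.85 log units; beyond the scatter), shows that the group here can move the number a great deal. Compound 3 shows a different amine giving a value close to compound 2. Compound 4 is therefore expected to lose only a little, an estimated step of a 5.0-fold higher number from compound 2 to compound 4 (0.70 log units; beyond the scatter), giving about 1 nM (range 0.2 nM to 6 nM).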

Compound 4, inhibition constant: 0.6 nM
Compound 4: middle estimate off by 1.7-fold (0.22 log units), on the high side; the range from low to high includes it.
By their numbers in this assay, from the lowest: compounds 2, 3 and 4 (each within the scatter of the next, the first and the last beyond it); then compound 1.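

Replacing dipropylamino with the larger 4-phenylpiperidin-1-yl, which brings two rings, gives a 3.0-fold higher number from compound 2 to compound 4 (0.48 log units; beyond the scatter) in this assay, a modest loss at this carbon next to the ring nitrogen. The same group still gives a 23-fold lower number from compound 1 to compound 4 (1.37 log units; beyond the scatter), so the large gain over (5-chloro-2-methylphenyl)amino is not unique to dipropylamino. Nothing available explains why these groups differ.

As far as these compounds go, it remains open how much the phenyl ring contributes. A plain piperidine or a morpholine at this carbon would test that.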